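This account rests on a few compounds, and the source may have more. Where it says the series, first, only, none or still open, it means among the compounds named here.

Measured compounds:
- compound 1 `C/C=C1/[C@H](O[C@@H]2O[C@H](CO)[C@@H](O)[C@H](O)[C@H]2O)OC=C(C(=O)OC)[C@H]1CC(=O)O`: > 15000 nM
- compound 2 `C/C=C1/[C@H](O[C@@H]2O[C@H](CO)[C@@H](O)[C@H](O)[C@H]2O)OC=C(C(=O)OC)[C@H]1CC(=O)OCCc1ccc2c(c1)OCCO2`: > 20000 nM
- compound 3 `C/C=C1/[C@H](O[C@@H]2O[C@H](CO)[C@@H](O)[C@H](O)[C@H]2O)OC=C(C(=O)OC)[C@H]1CC(=O)OCCc1ccccc1`: 11000 nM

For the measured compounds named here, in a functional assay on SK-BR-3 cells (Homo sapiens) for antiproliferative activity, read by MTT assay, with a stated time of 72 h (a lower number here means a stronger inhibitor, a higher number a weaker inhibitor), compound 3 gives 11000 nM, and this is the only outright number among the three. For compound 1 the value > 15000 nM is a limit of the assay, not a number. For compound 2 the value > 20000 nM is likewise a limit of the assay. The step of an at least 1.3-fold lower number from compound 1 to compound 3 (0.13 log units; that floor lies within the scatter) shows phenethyl in place of hydrogen on the ester oxygen, and the step of an at least 1.8-fold lower number from compound 2 to compound 3 (0.25 log units; that floor lies within the scatter) shows phenyl in place of the benzodioxinyl ring on the same chain; both have floors that sit within the scatter, so they set no firm direction.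

Compound 4 `C/C=C1/[C@H](O[C@@H]2O[C@H](CO)[C@@H](O)[C@H](O)[C@H]2O)OC=C(C(=O)OC)[C@H]1CC(=O)OCc1ccc(OC)c(OC)c1` carries the change (3,4-dimethoxyphenyl in place of benzyl on a saturated chain carbon bound to an oxygen next to a carbonyl group), read one bond further out as phenethyl to 3,4-dimethoxybenzyl. The nearest comparison is compound 2, where an aromatic ring bearing two oxygens on this chain gave only a limit, so a step in this assay toward a weaker inhibitor is expected, though of unreadable size. Compound 4 is therefore estimated at 16000 nM, within 6000 nM to 40000 nM, which means an expected step of a 1.5-fold higher number from compound 3 to compound 4 (0.16 log units; within the scatter).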

Compound 4, half-maximal inhibitory concentration: > 15000 nM
Compound 4: no number, only a limit; the forecaster's own chance of this, stated with the estimate: 45%; the middle value lies beyond the limit too.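

In this assay the reading for compound 4 is a limit of the assay and not a number: the limit of > 15000 nM in this assay, at which 2 of the 4 values shown sit.

Putting 3,4-dimethoxybenzyl in the place of phenethyl gives an at least 1.3-fold higher number from compound 3 to compound 4 (0.13 log units; that floor lies within the scatter), so this change, like the earlier ones, sets no firm direction, and the steps that link compound 4 to compound 1 and compound 2 cannot be read at all. What compound 4 adds is a second ring carrying two oxygens that yields only a limit, as compound 2 does, which leaves compound 3, with its bare phenyl ring, as the only one of the four with an outright number, although compound 1, with no ring at all, also stops at a limit.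

The compounds shown leave open whether the two methoxy groups or the shorter chain matters more, since compound 4 changes both at once, and a plain benzyl ester or a 3,4-dimethoxyphenethyl ester would pull the two apart. For the compounds shown here, it also stays open how a ring with an amine or a single methoxy group on this chain would read, and whether any ester here can come far below the one number available.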